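Removing one chloro from compound 1: what to expect

A few compounds are considered here, and "the series" means these few. Any claim that something is new, unique, unknown or untested is made for them only; others in the source may bear on it.

Measured so far:
compound 1 `ClCc1cccc(Cn2cnc3nc(Cl)nc(Cl)c32)c1`: 3380 nM
compound 2 `ClCc1ccccc1Cn1cnc2nc(Cl)nc(Cl)c21`: 35500 nM

Of the compounds shown here, two have been tested in a functional assay on SF-295 cells (Homo sapiens) for cytotoxicity, read by sulforhodamine B assay, with a stated time of 48 h; on this read-out higher numbers stand for weaker inhibition of growth and lower numbers for stronger inhibition of growth. Compound 1 `ClCc1cccc(Cn2cnc3nc(Cl)nc(Cl)c32)c1` gives 3380 nM, the lower of the two numbers, so it is the stronger growth inhibitor here. Compound 2 `ClCc1ccccc1Cn1cnc2nc(Cl)nc(Cl)c21` gives 35500 nM, a gap that lies beyond the usual scatter. Within the data shown here, the two differ only in where the chloromethyl group sits on the pendant benzyl ring, and no single step has been computed for this pair, so only the two values speak.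

Compound 3 `ClCc1cccc(Cn2cnc3ncnc(Cl)c32)c1` has not yet been measured. It differs from compound 1 by one change: hydrogen in place of chloro on an aromatic carbon. The shared core of compound 1 thus keeps one chloro and loses the other. Among the measured compounds shown here, no measured pair shows the effect of this change, so the expectation rests on a guess of a modest loss: the step of a 2.4-fold higher number from compound 1 to compound 3 (0.37 log units; beyond the scatter) is expected to run toward a higher number. Compound 3 is estimated at 8000 nM, with a range from 2000 nM to 32000 nM.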

Compound 3, concentration for total growth inhibition: 19100 nM
Beside the measured number, compound 3's estimate is 2.4-fold (0.38 log units) below it; the measured number falls inside the stated range.
By their numbers in this assay, from the lowest: compound 1; then compounds 3 and 2 (each within the scatter of the next).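

Hydrogen in place of chloro on the aromatic carbon between two ring nitrogen atoms gives a 5.7-fold higher number from compound 1 to compound 3 (0.75 log units; beyond the scatter) in this assay, so this chloro contributes to the growth inhibition seen with compound 1. The earlier pair differed only in where the chloromethyl group sits on the pendant benzyl ring, whereas this step shows that a single atom on the shared core also changes the read-out beyond the scatter. Among these compounds, nothing measured so far explains why this loss occurs.

The compounds shown leave open how an amine, a methoxy group or a longer chain on this carbon would compare with chloro or hydrogen. They also leave open what the remaining chloro on the core contributes, and whether removing the first chloro would cost as much with the chloromethyl group in its other position.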